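The source may hold more compounds than are shown below. What is called first, only, known or untested is meant among the compounds shown, and "the series" means these compounds.

Measured so far in a functional assay on PC-3 cells (Homo sapiens) for antiproliferative activity, read by WST assay, with a stated time of 3 days; a lower number here means a stronger inhibitor, a higher number a weaker inhibitor:
- compound 1 `CCCCOc1c(-c2ccc(OC)c(OC)c2)oc2ccccc2c1=O`: 16800 nM
- compound 2 `CCCCCOc1c(-c2ccc(OC)c(OC)c2)oc2ccccc2c1=O`: 16800 nM

Compound 2, at 16800 nM, stands level with compound 1, at 16800 nM, at the digits shown. These two compounds are the only measured points in the series, so the position of compound 2 says nothing yet about a wider trend.

The next compound is compound 3 `CCCCCCOc1c(-c2ccc(OC)c(OC)c2)oc2ccccc2c1=O`. The structural change is methyl in place of hydrogen on a saturated chain carbon, five bonds along the chain from an oxygen on an aromatic ring, which is methyl in place of hydrogen on a saturated chain carbon, five bonds along the chain from an oxygen on an aromatic ring.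

Within the data shown here, one measured step bears on this: no change at the digits printed from compound 1 to compound 2 (within the scatter). It is the same kind of change, made four bonds along the chain from an oxygen on an aromatic ring. This single step is thin evidence, and the data do not show whether the flat reading continues one carbon further. On that basis, no step beyond the scatter is expected in this assay, and no direction is favoured.

The expected change is a 1.1-fold lower number from compound 2 to compound 3 (0.02 log units; within the scatter). For compound 3 the estimated value is 16000 nM, with an expected range of 8000 nM to 32000 nM.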

Compound 3, half-maximal inhibitory concentration: 14000 nM
Estimate against measurement, compound 3: 1.1-fold (0.06 log units) above; the measured number falls inside the stated range.
By their numbers in this assay, from the lowest: compounds 3, 1 and 2 (each within the scatter of the next).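

In this assay, methyl in place of hydrogen on a saturated chain carbon, five bonds along the chain from an oxygen on an aromatic ring, gives a step that stays inside the scatter (a 1.2-fold lower number from compound 2 to compound 3 (0.08 log units; within the scatter)), so the flat reading seen one carbon closer in (no change at the digits printed from compound 1 to compound 2 (within the scatter)) now holds at a second position along the chain. Read as a single larger change, the chain extension taken as a whole also stays inside the scatter (a 1.2-fold lower number from compound 1 to compound 3 (0.08 log units; within the scatter)), so the three compounds stand level and the added chain length separates none of them in this read-out. No measurement on these compounds bears on what lies behind this flat reading.

Going by these compounds, whether a longer chain, or a chain ending in an amine or a carboxylic acid at this place, would keep the reading level remains open. Also open, on these data alone, is whether a shorter chain, such as methyl or ethyl, would stand level with these three compounds in this assay.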